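The source may report more compounds than this note shows. Statements on the series, on what has been measured and on what is new or still open speak of the compounds shown alone.

Compound 2 `CCCCCCCCCCCC(=O)OC[C@H](CSC[C@@H](N)C(=O)NC(C)CCc1ccccc1)OC(=O)CCCCCCCCCCC` stands second highest among the three numbers measured in an assay on HEK293 cells for agonist activity at Toll-like receptor 2 (Homo sapiens); a lower number here means that less compound is needed, a higher number that more compound is needed for the effect: compound 2 gives 160 nM, compound 1 `CCCCCCCCCCCC(=O)OC[C@H](CSC[C@@H](N)C(=O)NCCCCCCO)OC(=O)CCCCCCCCCCC` gives 33 nM, and compound 3 `CCCCCCCCCCCC(=O)OC[C@H](CSC[C@@H](N)C(=O)N[C@@H](CO)C(=O)NCCOCCOCCOCCC(=O)O)OC(=O)CCCCCCCCCCC` gives 4940 nM. The unmeasured compound 4 `CCCCCCCCCCCC(=O)OC[C@H](CSC[C@@H](N)C(=O)NCCCN)OC(=O)CCCCCCCCCCC` differs from compound 2 by 3-aminopropyl in place of 1-methyl-3-phenylpropyl on an amide-type nitrogen. For the measured compounds named here, only one measured step concerns this same amide-type nitrogen: a 4.8-fold higher number from compound 1 to compound 2 (0.69 log units; beyond the scatter), in which 6-hydroxyhexyl was exchanged for 1-methyl-3-phenylpropyl. Moving back from 1-methyl-3-phenylpropyl to 3-aminopropyl, a group more like 6-hydroxyhexyl than like the phenyl-bearing one, suggests a step downward of roughly that size. Compound 4 is therefore expected to give about 50 nM, in a range from 15 nM to 200 nM. That estimate means an expected step of a 3.2-fold lower number from compound 2 to compound 4 (0.51 log units; beyond the scatter).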

Compound 4, half-maximal effective concentration: 1960 nM
Estimate against measurement, compound 4: 39-fold (1.59 log units) below; measured number above the stated range.
By their numbers in this assay, from the lowest: compound 1; then compound 2; then compound 4; then compound 3.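

In this assay, for the compounds shown here, the single earlier step on this amide-type nitrogen did not predict the outcome: 3-aminopropyl in place of 1-methyl-3-phenylpropyl gives a 12-fold higher number from compound 2 to compound 4 (1.09 log units; beyond the scatter) and so moves upward. The step of a 59-fold higher number from compound 1 to compound 4 (1.77 log units; beyond the scatter) is larger still, and it changes chain length and chain end together, with amino in place of 3-hydroxypropyl.

The compounds shown do not separate those two changes; a 6-aminohexyl group or a 3-hydroxypropyl group on the same nitrogen would do so. Nothing available here explains either step.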